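Tert-butyl in place of methyl on the weakest compound

This account rests on a few compounds, and the source may have more. Where it says the series, first, only, none or still open, it means among the compounds named here.

In a functional assay on brain (Rattus norvegicus, strain Wistar) for inhibition (a lower number here means a stronger inhibitor, a higher number a weaker inhibitor), compound 3 (`Cc1ccc(-c2c(C)[nH]c(=O)n2C)cc1`) gives 85300 nM as the highest of three numbers and is the weakest inhibitor so far, with both gaps beyond the scatter. Compound 1 (`CCCCc1ccc(-c2c(CC)[nH]c(=O)n2C)cc1`) stands at 13900 nM and compound 2 (`CCCCc1ccc(-c2c(C)[nH]c(=O)n2C(C)C)cc1`) at 10700 nM as the two lower numbers. Within the data shown here, each of these two carries a butyl chain where compound 3 has methyl, and each also differs in a second place, so no single-place step is available.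

The change tert-butyl in place of methyl on an aromatic carbon turns compound 3 into compound 4 (`Cc1[nH]c(=O)n(C)c1-c1ccc(C(C)(C)C)cc1`) with tert-butyl in place of methyl on an aromatic carbon. Among the measured compounds shown here, the only guide is the lower numbers of compounds 1 and 2, which do not isolate this place, so the expectation is loose. In this assay the expected step is a 4.3-fold lower number from compound 3 to compound 4 (0.63 log units; beyond the scatter) toward stronger inhibition, beyond the scatter. The estimate for compound 4 is 20000 nM (expected range 8000 nM to 55000 nM).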

Compound 4, half-maximal inhibitory concentration: 8400 nM
The estimate for compound 4 lay 2.4-fold (0.38 log units) above the measured number; the measured number falls inside the stated range.
By their numbers in this assay, from the lowest: compounds 4, 2 and 1 (each within the scatter of the next); then compound 3.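

In this assay, among these compounds, the change from methyl to tert-butyl on the aromatic carbon gives a 10-fold lower number from compound 3 to compound 4 (1.01 log units; beyond the scatter) and is the first single-place step, which shows that this position alone can move the number by a large step. The entering group adds only carbon and no hydrogen-bond donor or acceptor, so the step needs no added donor, acceptor or net charge at this position. The steps from compound 4 to compound 1 and compound 2 cannot be read, since those pairs differ in more than one place, and no measurement at hand accounts for the size of the step.

Open, as far as these compounds go, is how a straight butyl chain compares with tert-butyl at this position on an otherwise unchanged core. Also open, from the compounds shown here alone, is whether an amine or a carboxylic acid is tolerated there.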